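This account rests on a few compounds, and the source may have more. Where it says the series, first, only, none or still open, it means among the compounds named here.

Of the compounds shown here, three with a shared core have been measured in an assay on HEK293 cells for activation of Kir3.1/Kir3.2 (Homo sapiens), read by thallium flux; a lower number here means that less compound is needed, a higher number that more compound is needed for the effect. Compound 1 `Cc1cc(NC(=O)Cn2nnc(-c3ccccc3)n2)n(C2CCC(C)(C)CC2)n1` gives only a limit in this assay, > 221 nM. Compound 2 `Cc1cc(NC(=O)Cn2nnc(-c3ccccc3)n2)n(Cc2ccccc2)n1` gives 495 nM, and compound 3 `Cc1cc(NC(=O)Cn2nnc(-c3cccnc3)n2)n(C2CCCCC2)n1` gives 1930 nM, the higher of the two numbers; its nearest neighbour is compound 2, whose lower number lies beyond the scatter. For the measured compounds named here, the single step between compounds that differ in one place, a step that the limit leaves unreadable from compound 1 to compound 2, is left unreadable by the limit. Compound 4 `Cc1cc(NC(=O)Cn2nnc(-c3ccc(F)cc3)n2)n(C2CCCCC2)n1` is derived from compound 3 by 4-fluorophenyl in place of pyridin-3-yl on an aromatic carbon. Going by the values given here, no measured step touches this position; compound 2 and compound 3 differ both here and on the aromatic nitrogen, so their two values alone cannot be split between the two changes. The step from compound 3 to compound 4 is therefore expected to be modest, a 2.1-fold lower number from compound 3 to compound 4 (0.33 log units; beyond the scatter), with its direction uncertain. Compound 4 is estimated at 900 nM, within 300 nM to 2700 nM.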

Compound 4, half-maximal effective concentration: 180 nM
The estimate for compound 4 lay 5.0-fold (0.70 log units) above the measured number, outside the stated range (below it).
By their numbers in this assay, from the lowest: compound 4; then compound 2; then compound 3.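

In this assay, 4-fluorophenyl in place of pyridin-3-yl gives an 11-fold lower number from compound 3 to compound 4 (1.03 log units; beyond the scatter), so the group on this aromatic carbon alone moves the number by a large step. For the compounds shown here, the earlier compounds differed here only together with a change on the aromatic nitrogen, which makes this the first step to isolate this position. Nothing shown gives a cause for this step. The compounds shown leave open how much of the step belongs to the ring nitrogen that leaves and how much to the fluorine that enters. Also open, going by these compounds, is how a methoxy group or an amine on this aromatic ring would read.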